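The compounds below may be only part of what the source reports. "The series", "measured", "known", "first", "only" and "open" are said of these compounds alone.

Measured in an ADME assay on SH-SY5Y cells (Homo sapiens) for cytotoxicity, read by MTT assay, with a stated time of 72 h; a higher number here means a weaker inhibitor, a lower number a stronger inhibitor:
- compound 1 `COc1ccc(C(=O)N2CCN(CC(=O)N3CCN(CCCc4c[nH]c5ccc(OC)cc45)CC3)CC2)cc1`: 190000 nM
- compound 2 `COc1ccc2[nH]cc(CCCN3CCN(C(=O)CN4CCN(C(=O)c5ccc(F)cc5)CC4)CC3)c2c1`: > 200000 nM, a limit of the assay

Compound 2 has only a limit and no number of its own: it sits at the limit of > 200000 nM in this assay, at which 1 of the 2 values shown sits. Compound 3 `COc1ccc2[nH]cc(CCCN3CCN(C(=O)CN4CCN(C(=O)c5cccc(F)c5)CC4)CC3)c2c1` is made from compound 2 by one change, (3-fluorophenyl in place of 4-fluorophenyl on a carbonyl carbon), with 3-fluorophenyl in place of 4-fluorophenyl on a carbonyl carbon. Among the measured compounds shown here, only one measured step can serve as a guide, and it is a different change: fluoro in place of methoxy on an aromatic carbon, an at least 1.0-fold higher number from compound 1 to compound 2 (0.02 log units; that floor lies within the scatter). For the measured compounds named here, that step shows no shift beyond the scatter, and no measured step tests moving the fluorine. No step beyond the scatter is therefore expected in this assay, in either direction. The expected step is a number no higher from compound 2 to compound 3 (the limit leaves the size open). Compound 3 is estimated at 200000 nM, with an expected range of 110000 nM to 350000 nM.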

Compound 3, half-maximal inhibitory concentration: > 200000 nM
Compound 3 gave a limit, no number; the forecaster's own chance of this, stated with the estimate: 55%; the middle value lies on the limit itself.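

In this assay compound 3, like compound 2, gives only a limit, so 3-fluorophenyl on this carbonyl carbon joins 4-fluorophenyl without yielding a number, and the step between these two compounds cannot be read. Against the methoxy compound, the new fluorine placement gives an at least 1.0-fold higher number from compound 1 to compound 3 (0.02 log units; that floor lies within the scatter), which matches the floor already printed for the other fluorine placement, an at least 1.0-fold higher number from compound 1 to compound 2 (0.02 log units; that floor lies within the scatter). The values at this carbonyl carbon now gather at one ceiling: the limit of > 200000 nM in this assay, at which 2 of the 3 values shown sit.

Going by these compounds, neither fluorophenyl compound has a number of its own, so whether moving the fluorine changes anything in this assay remains open. Also open, on these data alone, is whether an amine or a carboxylic acid on the phenyl ring would give a number clear of the limit.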